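This account rests on a few compounds, and the source may have more. Where it says the series, first, only, none or still open, it means among the compounds named here.

In a functional assay on HeLa cells (Homo sapiens) for antiproliferative activity, read by CCK-8 assay, with a stated time of 72 h (a higher number here means a weaker inhibitor, a lower number a stronger inhibitor), compound 1 `Nc1ccccc1NC(=O)/C=C/c1ccc(CSc2ccc(F)cc2)cc1` has the entry "not determined" (no result reported), while compound 2 `Cc1ccc(SCc2ccc(C(=O)Nc3ccccc3N)cc2)cc1` gives 4250 nM. Among the measured compounds shown here, that is the only number, so compound 2 cannot yet be ranked against anything. Compound 3 `Cc1cc(C)cc(SCc2ccc(C(=O)Nc3ccccc3N)cc2)c1` differs from compound 2 in the group on the sulfur: 3,5-dimethylphenyl in place of 4-methylphenyl on a sulfur. For the measured compounds named here, no measured step is available to size this change, so no shift beyond the scatter is expected, with only a slight lean towards stronger inhibition. The expected step is a 1.2-fold lower number from compound 2 to compound 3 (0.08 log units; within the scatter). For compound 3 the estimated value is 3500 nM, with an expected range of 1500 nM to 8500 nM.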

Compound 3, half-maximal inhibitory concentration: 2090 nM
The estimate for compound 3 lay 1.7-fold (0.22 log units) above the measured number, within the range that was stated.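

In this assay, among the compounds shown here, the group on the sulfur is the first place with a sized change: 3,5-dimethylphenyl in place of 4-methylphenyl gives a 2.0-fold lower number from compound 2 to compound 3 (0.31 log units; beyond the scatter), a modest step. Both groups are carbon-only aromatic rings with no hydrogen-bond donors or acceptors and no net charge. Nothing available accounts for the shift. Going by these compounds, it remains open whether an amine or a carboxylic acid on this ring, or a longer chain in place of the ring, would move the number further. A single step also cannot show whether the trend extends beyond these two compounds.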